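Aryl amide series: the step from compound 3 to compound 4

The source may hold more compounds than are shown below. What is called first, only, known or untested is meant among the compounds shown, and "the series" means these compounds.

Values in a functional assay on MDA-MB-231 cells (Homo sapiens) for cytotoxicity, read by MTT assay, with a stated time of 72 h; on this read-out higher numbers stand for weaker inhibition and lower numbers for stronger inhibition:
- compound 1 `O=C(CN1CCN(c2nnc(Cc3ccccc3)c3ccccc23)CC1)Nc1ccc(F)c(F)c1` gives 2750 nM
- compound 2 `Cc1ccccc1NC(=O)CN1CCN(c2nnc(Cc3ccccc3)c3ccccc23)CC1` gives 17300 nM
- compound 3 `O=C(CN1CCN(c2nnc(Cc3ccccc3)c3ccccc23)CC1)Nc1cccc(F)c1` gives 3730 nM

Compound 3 stands level with compound 1 within the scatter, and compound 2 lies well apart, with a 4.6-fold lower number from compound 2 to compound 3 (0.67 log units; beyond the scatter). Compound 4 `O=C(CN1CCN(c2nnc(Cc3ccccc3)c3ccccc23)CC1)Nc1ccc(F)c(Cl)c1` carries 3-chloro-4-fluorophenyl in place of 3-fluorophenyl on an amide-type nitrogen. The closest measured change is a 1.4-fold higher number from compound 1 to compound 3 (0.13 log units; within the scatter), a swap of hydrogen for fluoro that stays within the scatter. The larger 6.3-fold higher number from compound 1 to compound 2 (0.80 log units; beyond the scatter) involves 2-methylphenyl, which plays no part here. For the measured compounds named here, no chlorine-bearing compound has been measured. The expected step is a 1.3-fold lower number from compound 3 to compound 4 (0.12 log units; within the scatter), so none beyond the scatter is expected. For compound 4 the estimate is 2800 nM, with an expected range of 1100 nM to 6500 nM.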

Compound 4, half-maximal inhibitory concentration: 7360 nM
Compound 4: middle estimate off by 2.6-fold (0.42 log units), on the low side; the measured number lies above the stated range.
By their numbers in this assay, from the lowest: compounds 1, 3 and 4 (each within the scatter of the next, the first and the last beyond it); then compound 2.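

Swapping one fluoro for chloro on the aromatic ring moves the number beyond the scatter (a 2.7-fold higher number from compound 1 to compound 4 (0.43 log units; beyond the scatter)), which the hydrogen-for-fluoro change between compound 1 and compound 3 did not do. Going from 3-fluorophenyl to 3-chloro-4-fluorophenyl stays within the scatter (a 2.0-fold higher number from compound 3 to compound 4 (0.30 log units; within the scatter)). The chlorine-bearing ring also remains clear of the 2-methylphenyl compound (a 2.4-fold lower number from compound 2 to compound 4 (0.37 log units; beyond the scatter)).

No measurement available here accounts for these steps. Open, from the compounds shown here alone, is how bromo, methoxy or trifluoromethyl on this ring would read, and whether a pyridyl ring could replace the phenyl.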